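Chain-lengthened Esters and Their Cytotoxicity Read-out

The compounds below may be only part of what the source reports. "The series", "measured", "known", "first", "only" and "open" are said of these compounds alone.

Of the compounds shown here, three sharing one core have been tested, and a fourth is still to be measured. Compound 1 `CCOC(=O)CCC(=O)N1CCN(CCCOc2cc3c(Nc4ccc(F)c(Cl)c4)ncnc3cc2OC)CC1` carries an ethyl ester at the end of its side chain. In a functional assay on A549 cells (Homo sapiens) for cytotoxicity, read by MTT assay, with a stated time of 24 h, tested at 40 uM (on this read-out higher numbers stand for a weaker effect at the one concentration tested and lower numbers for a stronger effect), compound 1 gives 67.4%. Compound 2 `CCCOC(=O)CCC(=O)N1CCN(CCCOc2cc3c(Nc4ccc(F)c(Cl)c4)ncnc3cc2OC)CC1` differs by methyl in place of hydrogen on a saturated chain carbon, two bonds along the chain from an oxygen next to a carbonyl group, and in this assay compound 2 gives 80.9%; the step of a number 13.5 percentage points higher from compound 1 to compound 2 (beyond the scatter). Compound 3 `CCCCCCCCCCCCCCCCCOC(=O)CCC(=O)N1CCN(CCCOc2cc3c(Nc4ccc(F)c(Cl)c4)ncnc3cc2OC)CC1` carries a much longer chain, and in this assay compound 3 gives 85.2%; how its core differs from that of compound 1 is not broken down here, and its value sits within the scatter of compound 2.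

Compound 4 `CCCCCCCCCCCCCCCCCCOC(=O)CCC(=O)N1CCN(CCCOc2cc3c(Nc4ccc(F)c(Cl)c4)ncnc3cc2OC)CC1` is the unmeasured one. It differs from compound 3 by methyl in place of hydrogen on a saturated chain carbon, ten or more bonds along the chain from an oxygen next to a carbonyl group. Within the data shown here, this is the same kind of change as the one from compound 1 to compound 2, but the place along the chain is not the same, as the two differences just given show. The step from compound 3 to compound 4 is expected to be a number 0.8 percentage points higher from compound 3 to compound 4 (within the scatter), smaller than the earlier one, because the move from compound 2 to compound 3 added many chain carbons yet compound 3 gives 85.2%, within the scatter of compound 2. Compound 4 is therefore estimated at 86%, with a range from 76% to 96%.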

Compound 4, a percentage reported as activity, at one concentration (the size of the read-out at that concentration, not a potency): 91%
Compound 4: middle estimate off by 5 percentage points, on the low side, within the range that was stated.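

In this assay, methyl in place of hydrogen on a saturated chain carbon, ten or more bonds along the chain from an oxygen next to a carbonyl group, gives a step that reads a number 5.8 percentage points higher from compound 3 to compound 4 (within the scatter). Set beside the earlier case of the same kind of change, the two steps cannot be told apart: the same change on two cores in this assay, a number 13.5 percentage points higher (beyond the scatter) from compound 1 to compound 2 and a number 5.8 percentage points higher (within the scatter) from compound 3 to compound 4, 7.7 percentage points apart, within the scatter of two such steps. This shows only that the two cases do not disagree; it does not show that the change carries the same size from one core to another, for the methyl sits at a different place along the chain in each case, one step lies beyond the scatter while the other lies within it, and two steps are too few to make a rule.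

The compounds shown leave open what a methyl ester, or a chain of middling length such as an octyl ester, would give in this assay. They also leave open how a branched chain, or a carboxylic acid in place of the ester, would read on the shared core.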